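A few compounds are considered here, and "the series" means these few. Any claim that something is new, unique, unknown or untested is made for them only; others in the source may bear on it.

Measured so far:
compound 1, `COc1cc(/C=C/C(=O)OC[C@H](Cc2ccc(O)c(OC)c2)[C@H](CO)Cc2ccc(O)c(OC)c2)ccc1O`: 33.1 ug/mL
compound 2, `C=C[C@@]1(C)COC(=O)C1(O)C(=O)/C=C(\O)c1ccccc1`: 33.7 ug/mL

In a functional assay on K562 cells (Homo sapiens) for cytotoxicity, read by MTT assay, with a stated time of 48 h (a lower number here means a stronger inhibitor, a higher number a weaker inhibitor), compound 2 stands at the higher of the two numbers, but compound 1 sits within the scatter of it, so the two cannot be told apart. Compound 3, `C=C[C@@]1(C)COC(=O)C1C(=O)/C=C(\O)c1ccccc1`, has not been measured yet. It differs from compound 2 in one place: hydrogen in place of hydroxy on a saturated ring carbon. Within the data shown here, no measured pair shows what such a change does here, so the data give no direction to lean on. The step of a 1.1-fold lower number from compound 2 to compound 3 (0.05 log units; within the scatter) is expected to stay within the usual scatter. Compound 3 is therefore estimated at 30 ug/mL, within a range from 12 ug/mL to 75 ug/mL.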

Compound 3, half-maximal inhibitory concentration: 20 ug/mL
Beside the measured number, compound 3's estimate is 1.5-fold (0.18 log units) above it, within the range that was stated.
By their numbers in this assay, from the lowest: compounds 3, 1 and 2 (each within the scatter of the next).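

In this assay hydrogen in place of hydroxy on a saturated ring carbon gives a 1.7-fold lower number from compound 2 to compound 3 (0.23 log units; within the scatter) and so shows that, between these two compounds, this change cannot be told apart from the scatter. The hydroxy at this position is therefore not shown to be needed for the cytotoxicity read here. Nothing available explains this small step. From the compounds shown here alone, what stays open is whether a larger or charged group on this ring carbon, such as an amine, a methoxy group or a carboxylic acid, would shift the number beyond the scatter.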